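Notes on a pyridin-2-yl to phenyl swap

This account rests on a few compounds, and the source may have more. Where it says the series, first, only, none or still open, it means among the compounds named here.

Of the compounds shown here, three of the shared core have been tested so far in a functional assay on HEK293 cells for agonist activity at Toll-like receptor 8 (Homo sapiens), read by reporter gene assay; a higher number here means that more compound is needed for the effect, a lower number that less compound is needed. Compound 1 `Cc1ncc(CO)c2c(Nc3ccccn3)c(N)oc12` gives "not active" (no number reported) in this assay, with no number reported. Compound 3 `Cc1ncc(CO)c2c(Nc3cnccn3)c(NC(C)(C)C)oc12` likewise gives "not active" (no number reported) in this assay, again without a number. Within the data shown here, compound 2 `CCCCCNc1oc2c(C)ncc(CO)c2c1Nc1ccccn1` is the only member with a measured value: in this assay compound 2 gives 5810 nM. It therefore stands alone on the numbers shown; the two other entries carry no value to set beside it, and nothing can be said of how compound 2 ranks against compound 1 or compound 3.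

Compound 4 `CCCCCNc1oc2c(C)ncc(CO)c2c1Nc1ccccc1` is not yet measured. It differs from compound 2 in one place: phenyl in place of pyridin-2-yl on a nitrogen on an aromatic ring. The rest of the structure is unchanged. Among the measured compounds shown here, no pair of measured compounds differing in a single place is available, so a step of this kind has no precedent. The expected step is small, near the edge of the scatter, with no clear direction: a 1.0-fold higher number from compound 2 to compound 4 (0.01 log units; within the scatter). Compound 4 is expected to give about 6000 nM in this assay, within a range from 1500 nM to 25000 nM. Two of the three measured compounds returned no number; a result reported only as inactive remains possible for compound 4.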

Compound 4, half-maximal effective concentration: 2250 nM
Beside the measured number, compound 4's estimate is 2.7-fold (0.43 log units) above it; measured number inside the range.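

In this assay, among these compounds, phenyl in place of pyridin-2-yl on a nitrogen on an aromatic ring gives a 2.6-fold lower number from compound 2 to compound 4 (0.41 log units; beyond the scatter), the only single-place step so far and the first sign that this position responds to a change of ring. The earlier compounds shown here could not show this, since only one of them carried a number. The swap removes the ring nitrogen, and with it the one hydrogen-bond acceptor counted on the leaving group, yet compound 4 still gives 2250 nM, so a numerical response here does not depend on that ring nitrogen, and no measurement on hand accounts for the size or direction of the step.

Open, from the compounds shown here alone, is whether the step reflects the loss of the ring nitrogen alone or would also appear with other rings in the same place, such as pyridin-3-yl, pyridin-4-yl or a 4-fluorophenyl group. Also open, going by these compounds, is whether the same swap gives a step of similar size when the pentyl chain on the other nitrogen is replaced by a longer chain, such as octyl, or by a benzyl group.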